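This account rests on a few compounds, and the source may have more. Where it says the series, first, only, none or still open, it means among the compounds named here.

In a functional assay on BXPC-3 cells (Homo sapiens) for inhibition, read by MTT assay, with a stated time of 72 h (on this read-out lower numbers stand for stronger inhibition and higher numbers for weaker inhibition), the compounds share one amide-linked core and differ in the ring on the amide and in the substituent on the carbocyclic ring. Compound 1, `COc1cc(NC(=O)c2cnccn2)c2ncccc2c1`, gives 470 nM. Compound 2, `O=C(Nc1cc(F)cc2cccnc12)c1ncccn1`, reaches only the limit of this assay, > 10000 nM. That value is the limit of > 10000 nM in this assay, at which 1 of the 2 values shown sits, so compound 2 stands at the weak edge of what this assay reports, with no number of its own. Compound 3, `COc1cc(NC(=O)c2ncccn2)c2ncccc2c1`, has not yet been measured. The change from compound 2 to compound 3 is methoxy in place of fluoro on an aromatic carbon. Within the data shown here, no step between measured compounds carries this same change, so its size cannot be read from the data; compound 1 carries the same methoxy and gives 470 nM. The step from compound 2 to compound 3 is expected to run toward stronger inhibition, by an at least 3.3-fold lower number from compound 2 to compound 3 (0.52 log units; beyond the scatter). Compound 3 is estimated at 3000 nM, within 500 nM to 10000 nM.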

Compound 3, half-maximal inhibitory concentration: > 10000 nM
Compound 3 ended at the assay's limit; the forecaster's own chance of this, stated with the estimate: 40%; middle value at least 3.3-fold (0.52 log units) from the limit.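

In this assay, compound 3 gives only a limit of the assay, > 10000 nM. With the methoxy kept, pyrimidin-2-yl in place of pyrazin-2-yl on the carbonyl carbon brings an at least 21-fold higher number from compound 1 to compound 3 (1.32 log units; beyond the scatter), so the methoxy alone does not hold the inhibition, and the ring on the amide decides much of it in this pair. The change from fluoro to methoxy on this aromatic carbon cannot be read, since compound 2 and compound 3 stand at the same limit: the limit of > 10000 nM in this assay, at which 2 of the 3 values shown sit.

As far as these compounds go, how fluoro behaves with pyrazin-2-yl on the amide remains open. Also open, from the compounds shown here alone, is whether an amine or a longer alkoxy chain on this aromatic carbon, with pyrazin-2-yl kept, would retain the inhibition of compound 1.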